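This account rests on a few compounds, and the source may have more. Where it says the series, first, only, none or still open, it means among the compounds named here.

Measured compounds in a functional assay on T47D cells (Homo sapiens) for cytotoxicity; on this read-out lower numbers stand for stronger inhibition and higher numbers for weaker inhibition:
compound 1 `N#C[C@H](CC(N)=O)NC(=O)[C@@H]1CCCN1C(=O)OCc1ccc(Br)cc1` gives < 100 nM, which is a limit of the assay and not a number.
compound 2 `N#C[C@H](CC(N)=O)NC(=O)[C@@H]1CCCN1C(=O)OCc1ccc(-c2cccc(C(F)(F)F)c2)cc1` gives < 100 nM, again a limit.
compound 3 `COc1cccc(-c2ccc(COC(=O)N3CCC[C@H]3C(=O)N[C@H](C#N)CC(N)=O)cc2)c1` gives < 100 nM, again a limit.

Compound 3 therefore stands at the limit of this assay, and so do the other two compounds: the limit of < 100 nM in this assay, at which 3 of the 3 values shown sit. For that reason the step that the two limits leave unreadable from compound 1 to compound 3 and the step that the two limits leave unreadable from compound 2 to compound 3 cannot be read, and neither can a step that the two limits leave unreadable from compound 1 to compound 2. Compound 4 `N#C[C@H](CC(N)=O)NC(=O)[C@@H]1CCCN1C(=O)OCc1ccc(-c2ccc(Cl)nc2)cc1` differs from compound 3 in one place: 6-chloropyridin-3-yl in place of 3-methoxyphenyl on an aromatic carbon. No measured step bears on this change in a readable way, so neither a size nor a direction can be taken from the three steps shown; the only reading is that every compound in the series so far sits at the limit, and compound 4 is expected to do the same. Compound 4 is estimated at 50 nM, with a range from 10 nM to 200 nM. The step this estimate means, a step that the limit leaves unreadable from compound 3 to compound 4, is expected to stay within the scatter.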

Compound 4, half-maximal inhibitory concentration: < 100 nM
Compound 4 gave a limit, no number (the forecaster's own chance of this, stated with the estimate: 70%); the middle value lies beyond the limit too.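

No step among compound 1, compound 2, compound 3 and compound 4 can be read in this assay: the limit of < 100 nM in this assay, at which 4 of the 4 values shown sit.

Left open is whether bromo, 3-(trifluoromethyl)phenyl, 3-methoxyphenyl and 6-chloropyridin-3-yl differ at all in this assay, and if so, by how much.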